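Aryl swap at the saturated ring carbon of the series

A few compounds are considered here, and "the series" means these few. Any claim that something is new, unique, unknown or untested is made for them only; others in the source may bear on it.

Compound 1 `N#CC1=C(N)N(c2ccc(S(N)(=O)=O)cc2)C2=C(CCCC2)C1c1ccccc1` gives 30% in a functional assay on Ehrlich cells (Mus musculus) for cytotoxicity, read by trypan blue exclusion, with a stated time of 2 h, tested at 100 ug/mL; on this read-out lower numbers stand for a weaker effect and higher numbers for a stronger effect at the one concentration tested; compound 2 `COc1ccc(C2C(C#N)=C(N)N(c3ccc(S(N)(=O)=O)cc3)C3=C2CCCC3)cc1` gives 100%; compound 3 `N#CC1=C(N)N(c2ccc(S(N)(=O)=O)cc2)C2=C(CCCC2)C1c1cccc([N+](=O)[O-])c1` gives 12%, the lowest of the three, with a number 88 percentage points lower from compound 2 to compound 3 (beyond the scatter) and a number 18 percentage points lower from compound 1 to compound 3 (beyond the scatter). Compound 4 `N#CC1=C(N)N(c2ccc(S(N)(=O)=O)cc2)C2=C(CCCC2)C1c1c(O)ccc2ccccc12` is unmeasured. The change is 2-hydroxynaphthalen-1-yl in place of 3-nitrophenyl on a saturated ring carbon. All three measured steps bear on it, since each alters the group on the same saturated ring carbon: a number 70 percentage points higher from compound 1 to compound 2 (beyond the scatter), a number 18 percentage points lower from compound 1 to compound 3 (beyond the scatter) and a number 88 percentage points lower from compound 2 to compound 3 (beyond the scatter). Within the data shown here, removing 3-nitrophenyl alone moved the number upward in the step from compound 3 to compound 1, and no measured compound fell lower than compound 3, so a rise is expected, of uncertain size given the large spread of the three values; the expected step is a number 33 percentage points higher from compound 3 to compound 4 (beyond the scatter). Compound 4 is estimated at 45%, range 15% to 85%.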

Compound 4, a percentage reported as activity, at one concentration (the size of the read-out at that concentration, not a potency): 50%
Compound 4: middle estimate off by 5 percentage points, on the low side; the measured number falls inside the stated range.
By their numbers in this assay, from the lowest: compound 3; then compound 1; then compound 4; then compound 2.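

In this assay the saturated ring carbon tolerates a group of two aromatic rings carrying a hydroxyl: 2-hydroxynaphthalen-1-yl gives a number 20 percentage points higher from compound 1 to compound 4 (beyond the scatter) over phenyl and a number 38 percentage points higher from compound 3 to compound 4 (beyond the scatter) over 3-nitrophenyl. Two aromatic rings do not match 4-methoxyphenyl, however, with a number 50 percentage points lower from compound 2 to compound 4 (beyond the scatter) in the series. No measured evidence accounts for these differences.

Going by these compounds, whether the hydroxyl or the second aromatic ring carries the rise stays open, and a plain naphthalen-1-yl group would separate the two. On these data alone, how an aryl group bearing an amine or a carboxylic acid would read at this carbon also stays open.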